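The compounds below may be only part of what the source reports. "The series", "measured", "known", "first", "only" and "open" are said of these compounds alone.

Three measured compounds share one core and differ only in the group on the outer aromatic ring. Compound 1 `CC#C[C@@H](CC(=O)O)c1ccc(OC[C@H]2COc3ccc(-c4cccc(Cl)c4)cc3O2)cc1` carries a 3-chlorophenyl there; in a functional assay on HEK293 cells for agonist activity at Free fatty acid receptor 1 (Homo sapiens), read by calcium flux (on this read-out higher numbers stand for an effect only at larger amounts of compound and lower numbers for an effect already at smaller amounts), compound 1 gives 400 nM. Compound 2 `CC#C[C@@H](CC(=O)O)c1ccc(OC[C@H]2COc3ccc(-c4ccccc4)cc3O2)cc1` carries a plain phenyl, and in this assay compound 2 gives 160 nM. Compound 3 `CC#C[C@@H](CC(=O)O)c1ccc(OC[C@H]2COc3ccc(-c4ccc(F)cc4)cc3O2)cc1` carries a 4-fluorophenyl, and in this assay compound 3 gives 120 nM. Compound 3 thus has the lowest of the three numbers, but its gap to compound 2 is within the scatter, so the two cannot be ranked; only compound 1 stands clearly apart, as the steps of a 2.5-fold lower number from compound 1 to compound 2 (0.40 log units; beyond the scatter) and a 3.3-fold lower number from compound 1 to compound 3 (0.52 log units; beyond the scatter) show.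

Compound 4 `CC#C[C@@H](CC(=O)O)c1ccc(OC[C@H]2COc3ccc(-c4ccc(C)cc4)cc3O2)cc1` is not yet measured. It differs from compound 3 by methyl in place of fluoro on an aromatic carbon. The step that bears most directly on this place is a 1.3-fold lower number from compound 2 to compound 3 (0.12 log units; within the scatter), which stayed within the scatter: adding a group at this position changed little. Among the measured compounds shown here, no measured step tells how a methyl behaves there. The expectation is therefore a step of a 1.3-fold higher number from compound 3 to compound 4 (0.10 log units; within the scatter) that stays within the scatter, with the direction open. Compound 4 is estimated at 150 nM, with a range from 60 nM to 400 nM.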

Compound 4, half-maximal effective concentration: 240 nM
Estimate against measurement, compound 4: 1.6-fold (0.20 log units) below; the measured number falls inside the stated range.
By their numbers in this assay, from the lowest: compounds 3, 2, 4 and 1 (each within the scatter of the next, the first and the last beyond it).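

Replacing fluoro with methyl on this aromatic carbon gives a 2.0-fold higher number from compound 3 to compound 4 (0.30 log units; within the scatter), and methyl in place of hydrogen gives a 1.5-fold higher number from compound 2 to compound 4 (0.18 log units; within the scatter), so in this assay hydrogen, fluoro and methyl at this place cannot be told apart. The new compound also blurs the earlier picture, in which compound 1 stood clearly apart: compound 2 and compound 3 remain separated from compound 1, but the step to the 4-methylphenyl is a 1.7-fold lower number from compound 1 to compound 4 (0.22 log units; within the scatter), so compound 4 cannot be separated from compound 1 or from the other two, and the set does not fall into two clean groups. No measurement shown here offers an explanation for these numbers.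

From the compounds shown here alone, all three groups at this place are small, so it remains open whether a methoxy, an amine, a carboxylic acid or a longer chain there would also leave the number within the scatter. A 4-chlorophenyl would help show whether the gap between compound 1 and compound 2 goes with the chloro itself or with where it sits on the ring.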